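Aryl swap on the hydrazone carbon: compound 3 to compound 4

The source may hold more compounds than are shown below. What is called first, only, known or untested is meant among the compounds shown, and "the series" means these compounds.

The series shares one core and varies only the aryl group on a carbon with a double bond to nitrogen. Compound 1 `CN(C)CCn1cnnc1-c1cc(Oc2ccc(NC(=O)N/N=C/c3cc(C(C)(C)C)cc(C(C)(C)C)c3O)cc2F)ccn1` in a functional assay on A549 cells (Homo sapiens) for cytotoxicity, read by MTT assay, with a stated time of 72 h (on this read-out higher numbers stand for weaker inhibition and lower numbers for stronger inhibition), gives 980 nM. Compound 2 `CN(C)CCn1cnnc1-c1cc(Oc2ccc(NC(=O)N/N=C/c3ccc(O)c(Br)c3)cc2F)ccn1` gives 1370 nM in this assay, and compound 3 `CN(C)CCn1cnnc1-c1cc(Oc2ccc(NC(=O)N/N=C/c3ccccc3O[N+](=O)[O-])cc2F)ccn1` gives 1200 nM in this assay. All three numbers lie within the usual scatter of one another, so compound 3 cannot be set apart from compound 1 or compound 2 on these data.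

Among the compounds with values here, the single measured step at this position, a 1.1-fold lower number from compound 2 to compound 3 (0.06 log units; within the scatter), shows that exchanging one aryl group for another on this carbon left the number essentially unchanged.

Compound 4 `CN(C)CCn1cnnc1-c1cc(Oc2ccc(NC(=O)N/N=C/c3ccc(Cl)cc3)cc2F)ccn1` differs from compound 3 by 4-chlorophenyl in place of 2-(nitrooxy)phenyl on a carbon with a double bond to nitrogen. The change removes the double bond outside aromatic rings and the hydrogen-bond acceptors of the leaving group and brings in a chlorine instead. Within the data shown here, only the step from compound 2 to compound 3 bears on this change; as that step stayed within the scatter, no shift beyond the scatter is expected here, and no change at the digits printed from compound 3 to compound 4 (within the scatter) is the step expected. Compound 4 is therefore estimated at 1200 nM in this assay, with a range from 500 nM to 3000 nM.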

Compound 4, half-maximal inhibitory concentration: 780 nM
Estimate against measurement, compound 4: 1.5-fold (0.19 log units) above, and the stated range covers the measured number.
By their numbers in this assay, from the lowest: compounds 4, 1, 3 and 2 (each within the scatter of the next).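

Replacing 2-(nitrooxy)phenyl with 4-chlorophenyl on the carbon with a double bond to nitrogen gives a 1.5-fold lower number from compound 3 to compound 4 (0.19 log units; within the scatter) in this assay, so on these data the hydrogen-bond acceptors of the leaving group can be given up at this position without a shift beyond the scatter. Placing 4-chlorophenyl where 3-bromo-4-hydroxyphenyl stood gives a 1.8-fold lower number from compound 2 to compound 4 (0.24 log units; within the scatter), which extends the flat picture to a group with a single halogen as its only substituent and still produces no step beyond the scatter at this position. Nothing available here accounts for these numbers or says what lies behind them.

The groups shown at this carbon all hold a six-membered aromatic ring of carbon only, so it remains open whether a pyridyl ring, a saturated cyclohexyl group or a phenyl ring bearing a carboxylic acid or an aminomethyl group would stay within the same scatter. Also open, from the compounds shown here alone, is whether changing the dimethylaminoethyl chain of the shared core, rather than this aryl group, would move the number beyond the scatter.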